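This account rests on a few compounds, and the source may have more. Where it says the series, first, only, none or still open, it means among the compounds named here.

Compound 1, `CCCCCc1cc2ccccc2nc1-c1cn(CCC(F)(F)C(F)(F)C(F)(F)C(F)(F)C(F)(F)C(F)(F)C(F)(F)C(F)(F)F)nn1`, gives in a functional assay on COLO 205 cells (Homo sapiens) for cytotoxicity, read by MTT assay, with a stated time of 24 h (a lower number here means a stronger inhibitor, a higher number a weaker inhibitor), a value of > 100 ug/mL, which is a limit of the assay and not a number. Compound 2, `CCc1cc2ccccc2nc1-c1cn(CCC(F)(F)C(F)(F)C(F)(F)C(F)(F)C(F)(F)C(F)(F)C(F)(F)C(F)(F)F)nn1`, gives in this assay 95.2 ug/mL.

Within the data shown here, compound 2 therefore holds the only number in this assay; the other value shown is a limit. Compound 3, `CCCc1cc2ccccc2nc1-c1cn(CCC(F)(F)C(F)(F)C(F)(F)C(F)(F)C(F)(F)C(F)(F)C(F)(F)C(F)(F)F)nn1`, differs from compound 2 by methyl in place of hydrogen on a saturated chain carbon, two bonds along the chain from an aromatic carbon. Among the measured compounds shown here, only one measured step bears on this change, and it runs the other way: an at least 1.0-fold lower number from compound 1 to compound 2 (0.02 log units; that floor lies within the scatter), with compound 1 sitting at the limit described by the limit of > 100 ug/mL in this assay, at which 1 of the 2 values shown sits. That step is bounded by a limit and lies within the scatter, so no size of step beyond the scatter can be expected for compound 3 in this assay, in either direction. Compound 3 is accordingly estimated at 100 ug/mL, with a range from 60 ug/mL to 180 ug/mL, meaning an expected step of a 1.1-fold higher number from compound 2 to compound 3 (0.02 log units; within the scatter).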

Compound 3, half-maximal inhibitory concentration: > 100 ug/mL
Compound 3 was reported as a limit; the forecaster's own chance of this, stated with the estimate: 45%; the middle value sits exactly at the limit.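

In this assay, among these compounds, methyl in place of hydrogen at this saturated chain carbon gives an at least 1.0-fold higher number from compound 2 to compound 3 (0.02 log units; that floor lies within the scatter), so the one readable step for this change shows no size beyond the scatter. The step between compound 1 and compound 3 cannot be read, as both values are limits and not numbers. With compound 3, a second of the three compounds now rests on the limit, leaving compound 2 as the only one with a number, so lengthening the chain from ethyl to propyl gives no measurable size of effect here: the limit of > 100 ug/mL in this assay, at which 2 of the 3 values shown sit.

As far as these compounds go, how far compound 3 lies past its limit stays open. So does whether an amine or a carboxylic acid on this chain, in place of the plain alkyl end, would bring a readable number on the shared core.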